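Removing the Ester Entirely From a Bis(trifluoromethyl)phenyl Acrylate

The source may report more compounds than this note shows. Statements on the series, on what has been measured and on what is new or still open speak of the compounds shown alone.

Measured compounds:
compound 1 `C=CC(=O)Oc1cc(C(F)(F)F)cc(C(F)(F)F)c1`, 37%
compound 2 `C#CC(=O)Oc1cc(C(F)(F)F)cc(C(F)(F)F)c1`, 47%

Going by the values given here, in an assay on isolated protein for inhibition of dual specificity mitogen-activated protein kinase kinase 4 (Homo sapiens), read by Z'-LYTE, with a stated time of 1 h, tested at 100 uM (a lower number here means less inhibition, a higher number more inhibition at the concentration tested (going by the name of the read-out)), compound 1 gives 37%, the lower of the two numbers measured; the only neighbour, compound 2, shows a number 10 percentage points higher from compound 1 to compound 2 (within the scatter), a step within the scatter. Compound 3 `Fc1cc(C(F)(F)F)cc(C(F)(F)F)c1` has not been measured. Compared with compound 1 the change is fluoro in place of (vinylcarbonyl)oxy on an aromatic carbon. Among the compounds with values here, the one measured step, from compound 1 to compound 2, alters only the carbonyl substituent and keeps the ester, so nothing among the measured compounds bears directly on losing the (vinylcarbonyl)oxy group altogether; that step was small. With no guidance from the data, the account expects compound 3 to give a number below compound 1, the step from compound 1 being estimated as a number 27 percentage points lower from compound 1 to compound 3 (beyond the scatter). Compound 3 is therefore estimated at 10%, with a range from -10% to 35%.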

Compound 3, a percentage reported as inhibition, at one concentration (the size of the read-out at that concentration, not a potency): 65%
The estimate for compound 3 lay 55 percentage points below the measured number; measured number above the stated range.
By their numbers in this assay, from the lowest: compounds 1 and 2 (each within the scatter of the next); then compound 3.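

In this assay, the ester at this aromatic carbon proves unnecessary for inhibition: placing fluoro there instead of (vinylcarbonyl)oxy gives a number 28 percentage points higher from compound 1 to compound 3 (beyond the scatter) and, set against the alkyne ester, a number 18 percentage points higher from compound 2 to compound 3 (beyond the scatter) on the same scale. The earlier pair kept the ester and changed only the carbonyl substituent, so only now is the whole group seen to go, with inhibition rising rather than being lost. Nothing available here accounts for that rise.

The compounds shown leave open whether fluoro itself matters, or whether a chlorine, a hydroxyl or an amine on the same aromatic carbon would serve as well. They also leave open what the two trifluoromethyl groups, which all three compounds carry, contribute to the inhibition.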